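Bromo to chloro exchange on a phenoxy side chain

The compounds below may be only part of what the source reports. "The series", "measured", "known", "first", "only" and "open" are said of these compounds alone.

Three compounds have been measured in an assay on isolated protein for inhibition of Dihydrofolate reductase (Homo sapiens), read by spectrophotometry, using NADPH, with stated times of 5 s and 6 min, tested at 5 uM; on this read-out lower numbers stand for a weaker effect and higher numbers for a stronger effect at the one concentration tested:

compound 1, `NC1=NC2(CCOCC2)N(OCCCOc2ccccc2Cl)C(N)=N1`, gives 83.3%
compound 2, `NC1=NC2(CCOCC2)N(OCCCOc2ccccc2Br)C(N)=N1`, gives 83.8%
compound 3, `NC1=NC2(CCSCC2)N(OCCCOc2ccccc2Br)C(N)=N1`, gives 88.7%

Compound 1 and compound 2 share one core and differ in a single place: chloro in place of bromo on an aromatic carbon. On this read-out the exchange gives a number 0.5 percentage points lower from compound 2 to compound 1 (within the scatter), so the two numbers cannot be told apart.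

Compound 3 carries the same side chain as compound 2 on a different core; the difference between the two cores is not broken down here. The number of compound 3 lies within the scatter of both compound 2 and compound 1, so no order among the three compounds can be drawn from these data.

Compound 4, `NC1=NC2(CCSCC2)N(OCCCOc2ccccc2Cl)C(N)=N1`, has not yet been measured in this assay. It is related to compound 3 by chloro in place of bromo on an aromatic carbon, the same kind of change as that between compound 2 and compound 1, at the same place on the same side chain. For compound 4 a step of a number 0.7 percentage points lower from compound 3 to compound 4 (within the scatter) is expected. This expectation rests on compound 2 and compound 1, because a number 0.5 percentage points lower from compound 2 to compound 1 (within the scatter) was seen for the same exchange on the other core. Compound 4 is therefore estimated at 88%, with a likely range from 80% to 94%.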

Compound 4, a percentage reported as inhibition, at one concentration (the size of the read-out at that concentration, not a potency): 86.3%
Beside the measured number, compound 4's estimate is 1.7 percentage points above it; the measured number falls inside the stated range.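

On the core of compound 3, chloro in place of bromo gives a number 2.4 percentage points lower from compound 3 to compound 4 (within the scatter) in this assay, and the two steps for this exchange can be set side by side: the same change on two cores in this assay, a number 0.5 percentage points lower (within the scatter) from compound 2 to compound 1 and a number 2.4 percentage points lower (within the scatter) from compound 3 to compound 4, 1.9 percentage points apart, within the scatter of two such steps. In this series, then, the exchange carries from one core to the other without a step on either core that can be told from the scatter, and the two cores give no sign of answering to it differently. Among these compounds, this does not show that bromo and chloro are interchangeable in general, since it rests on only two pairs of compounds and on a read-out taken at one concentration, which gives the size of the effect at that concentration only, so a stronger or weaker effect at other concentrations could remain hidden.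

The compounds shown leave open how the read-out responds to other groups at this place on the phenoxy side chain, such as fluoro, methoxy or a nitrile. They also leave open whether the exchange behaves in the same way with a longer chain leading to the phenoxy group, or on cores other than these two.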